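Sulfur to benzylselanyl exchange on the nitrothiophene series

The source may hold more compounds than are shown below. What is called first, only, known or untested is meant among the compounds shown, and "the series" means these compounds.

Compound 1 `CS/C(=N\C(=O)c1csc([N+](=O)[O-])c1)NC(=O)c1csc([N+](=O)[O-])c1` is the starting point. In a functional assay on HepG2 cells (Homo sapiens) for cytotoxicity, read by MTT assay, with a stated time of 72 h (a higher number here means a weaker inhibitor of growth, a lower number a stronger inhibitor of growth), compound 1 gives only a limit, > 100000 nM, so its standing is given only by the limit of > 100000 nM in this assay, at which 1 of the 2 values shown sits. Among the compounds with values here, compound 2 `C[Se]/C(=N\C(=O)c1cc(-c2ccccc2)nc2ccccc12)NC(=O)c1cc(-c2ccccc2)nc2ccccc12`, built on a different core, gives 10100 nM in this assay; no step between compound 1 and compound 2 is counted, so the two values stand side by side and nothing more. Compound 3 `O=C(/N=C(/NC(=O)c1csc([N+](=O)[O-])c1)[Se]Cc1ccccc1)c1csc([N+](=O)[O-])c1` is not yet measured. It differs from compound 1 by a group of 8 heavy atoms (7 carbon, 1 selenium; one six-membered aromatic ring of carbon only) in place of a group of 2 heavy atoms (1 carbon, 1 sulfur; no ring), on a carbon with a double bond to nitrogen. Within the data shown here, no measured step covers this change; a modest shift toward stronger growth inhibition is expected, possibly still ending at the limit. The expected step is an at least 2.0-fold lower number from compound 1 to compound 3 (0.30 log units; that floor lies within the scatter). Compound 3 is estimated at 50000 nM, within 10000 nM to 200000 nM.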

Compound 3, concentration for total growth inhibition: 62800 nM
Estimate against measurement, compound 3: 1.3-fold (0.10 log units) below; the range from low to high includes it.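

With the core of compound 1 held fixed, benzylselanyl in place of methylsulfanyl, on a carbon with a double bond to nitrogen, moves the read-out in this assay from an assay limit to a measured number. The change reads as an at least 1.5-fold lower number from compound 1 to compound 3 (0.20 log units; that floor lies within the scatter). Only a floor can be given for this step, because one end of it is an assay limit: the limit of > 100000 nM in this assay, at which 1 of the 3 values shown sits.

On these data alone, it remains open whether the shift belongs to the selenium or to the benzyl group, a question that a methylselanyl or a benzylsulfanyl group on the core of compound 1 would separate. Also open, as far as these compounds go, is how a longer chain on the selenium, or an amine or a carboxylic acid on the benzyl ring, would read in this assay.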